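From thiophen-3-yl to 1-benzofuran-2-yl on the shared core

This account rests on a few compounds, and the source may have more. Where it says the series, first, only, none or still open, it means among the compounds named here.

For the measured compounds named here, in a functional assay on HL-60 cells (Homo sapiens) for antiproliferative activity, read by XTT assay, with a stated time of 72 h (a higher number here means a weaker inhibitor, a lower number a stronger inhibitor), compound 2 (`CN(C)c1ncnc2c1c(-c1ccsc1)cn2[C@@H]1O[C@H](CO)[C@@H](O)[C@H]1O`) gives 1920 nM and holds the lower of the two numbers so far. Compound 1 (`COc1ncnc2c1c(-c1cc3ccccc3o1)cn2[C@@H]1O[C@H](CO)[C@@H](O)[C@H]1O`) stands at 4470 nM in this assay and the gap between the two lies beyond the scatter.

Compound 3 (`CN(C)c1ncnc2c1c(-c1cc3ccccc3o1)cn2[C@@H]1O[C@H](CO)[C@@H](O)[C@H]1O`) differs from compound 2 in one place (1-benzofuran-2-yl in place of thiophen-3-yl on an aromatic carbon): 1-benzofuran-2-yl in place of thiophen-3-yl on an aromatic carbon. Going by the values given here, no measured pair shows this change alone. Among the compounds with values here, the only guide is compound 1, which also carries 1-benzofuran-2-yl and gives 4470 nM on the weaker side, though it differs from compound 2 in a second place as well. A modest move towards a higher number is therefore expected, with a 1.6-fold higher number from compound 2 to compound 3 (0.19 log units; within the scatter) as the estimated step. In this assay compound 3 is estimated at 3000 nM with 1000 nM to 9000 nM as the expected range.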

Compound 3, half-maximal inhibitory concentration: > 20000 nM
Compound 3: no number, only a limit (the forecaster's own chance of this, stated with the estimate: 5%); middle value at least 6.6-fold (0.82 log units) from the limit.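

In this assay, for the compounds shown here, the first reading of this change alone gives an at least 10-fold higher number from compound 2 to compound 3 (1.01 log units; beyond the scatter), so this aromatic carbon does not accept 1-benzofuran-2-yl and thiophen-3-yl alike when dimethylamino is present. With 1-benzofuran-2-yl held constant, dimethylamino in place of methoxy gives an at least 4.4-fold higher number from compound 1 to compound 3 (0.65 log units; beyond the scatter), so the outcome for this group also depends on the second place, even though compound 2 carries dimethylamino and holds the lowest number shown. Compound 3 gives > 20000 nM, which is a limit and not a number, so both steps fix only a minimum size: the limit of > 20000 nM in this assay, at which 1 of the 3 values shown sits.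

As far as these compounds go, how thiophen-3-yl behaves alongside methoxy remains open, so the dependence between the two places rests on a single pair of groups. A furan-2-yl group could show whether the added six-membered aromatic ring or the change from sulfur to oxygen accompanies the loss.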